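From methyl to 4-fluorophenyl on the shared core

The source may report more compounds than this note shows. Statements on the series, on what has been measured and on what is new or still open speak of the compounds shown alone.

Measured so far in an ADME assay on microsomes from liver (Rattus norvegicus) for metabolic stability, with a stated time of 10 min, tested at 0.5 uM; a higher number here means that more of the compound is left, a lower number that less of the compound is left:
compound 1 `Cc1noc(C)c1[C@@H]1C[C@@](C)(c2ccc(F)cc2F)N=C(N)S1`: 78%
compound 2 `CCc1noc(C)c1[C@@H]1C[C@@](C)(c2ccc(F)cc2F)N=C(N)S1`: 59%
compound 3 `Cc1onc(-c2ccccc2)c1[C@@H]1C[C@@](C)(c2ccc(F)cc2F)N=C(N)S1`: 13%

Of these three, compound 1 stands highest in this assay, with 78%. The unmeasured compound 4 `Cc1noc(-c2ccc(F)cc2)c1[C@@H]1C[C@@](C)(c2ccc(F)cc2F)N=C(N)S1` departs from it as follows: 4-fluorophenyl in place of methyl on an aromatic carbon. In words, this is 4-fluorophenyl in place of methyl on an aromatic carbon, next to the ring oxygen.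

The nearest measured change is phenyl in place of methyl on an aromatic carbon, which gave a number 65 percentage points lower from compound 1 to compound 3 (beyond the scatter). Phenyl in place of ethyl on an aromatic carbon gave a number 46 percentage points lower from compound 2 to compound 3 (beyond the scatter), so both steps that bring in a phenyl ended at the same low compound. The remaining step, methyl in place of hydrogen on a saturated chain carbon bound to an aromatic carbon, gave a number 19 percentage points lower from compound 1 to compound 2 (beyond the scatter), and it adds no aromatic ring. For the measured compounds named here, no measured compound carries a 4-fluorophenyl, so the comparison is indirect.

Going by compound 3 at 13%, a large downward step is expected in this assay. The expected change is a number 62 percentage points lower from compound 1 to compound 4 (beyond the scatter). Compound 4 is estimated at 16%, with an expected range from 5% to 38%.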

Compound 4, percent of the compound remaining: 88%
Beside the measured number, compound 4's estimate is 72 percentage points below it; the measured number lies above the stated range.
By their numbers in this assay, from the lowest: compound 3; then compound 2; then compounds 1 and 4 (each within the scatter of the next).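

In this assay, the step from methyl to 4-fluorophenyl on the aromatic carbon next to the ring oxygen gives a number 10 percentage points higher from compound 1 to compound 4 (within the scatter), so at this place a group of 7 heavy atoms with a six-membered aromatic ring is taken up without a step beyond the scatter. The earlier compounds shown here could suggest that bringing in an aromatic ring goes with a low number, yet compound 4 goes against that reading, while compound 3 remains low at 13% and differs from compound 4 in more than one place, so that pair cannot show what sets them apart. No measurement available here bears on why the large group leaves this read-out within the scatter of compound 1.

Whether the fluorine of the 4-fluorophenyl plays any part in this result remains open, since the only phenyl shown stands in compound 3. Also open, from the compounds shown here alone, is how far this place tolerates other groups in this assay, such as a pyridyl ring, a methoxy group on the phenyl ring, an amine or a longer chain.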